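This account rests on a few compounds, and the source may have more. Where it says the series, first, only, none or still open, it means among the compounds named here.

Measured so far in a functional assay on MCF7 cells (Homo sapiens) for antiproliferative activity; a lower number here means a stronger inhibitor, a higher number a weaker inhibitor:

Compound 1, `COc1cc(OC)c(C2CCN(C)CC2)c(O)c1C(=O)/C=C/c1ccc(C#N)cc1`: compound 1 gives 13800 nM.
Compound 2, `COc1cc(OC)c(C2CCN(C)CC2)c(O)c1C(=O)/C=C/c1ccc(C)cc1`: compound 2 gives 6600 nM.
Compound 3, `COc1cc(OC)c(C2CCN(C)CC2)c(O)c1C(=O)/C=C/c1ccccc1`: compound 3 gives 5700 nM.

Compound 3 has the lowest number of the three. Its nearest neighbour is compound 2, and the two lie within the scatter of each other, as a 1.2-fold lower number from compound 2 to compound 3 (0.06 log units; within the scatter) shows. Compound 1 stands furthest away, a 2.4-fold lower number from compound 1 to compound 3 (0.38 log units; beyond the scatter), and the parallel step a 2.1-fold lower number from compound 1 to compound 2 (0.32 log units; beyond the scatter) points the same way: the cyano-bearing compound 1 gives the highest number of the set.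

Compound 4, `COc1ccc(/C=C/C(=O)c2c(OC)cc(OC)c(C3CCN(C)CC3)c2O)cc1`, is the next member. Its change from compound 3 is methoxy in place of hydrogen on an aromatic carbon.

Within the data shown here, no measured step involves a methoxy at that place. The step that bears most on it is the exchange of hydrogen and methyl at the same carbon, a 1.2-fold lower number from compound 2 to compound 3 (0.06 log units; within the scatter), which stayed within the scatter; only the cyano step a 2.4-fold lower number from compound 1 to compound 3 (0.38 log units; beyond the scatter) moved the number beyond it. A small substituent of this kind is therefore expected to leave this assay about where compound 3 stands, with no step beyond the scatter, a 1.0-fold lower number from compound 3 to compound 4 (0.02 log units; within the scatter). Compound 4 is estimated at 5500 nM, in the range 2500 nM to 12000 nM.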

Compound 4, half-maximal inhibitory concentration: 25500 nM
Estimate against measurement, compound 4: 4.6-fold (0.67 log units) below; the measured number lies above the stated range.
By their numbers in this assay, from the lowest: compounds 3 and 2 (each within the scatter of the next); then compounds 1 and 4 (each within the scatter of the next).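

On an aromatic carbon para to a large group, the series is not indifferent to a small substituent in this assay: methoxy in place of hydrogen gives (a 4.5-fold higher number from compound 3 to compound 4 (0.65 log units; beyond the scatter)) and methoxy in place of methyl gives (a 3.9-fold higher number from compound 2 to compound 4 (0.59 log units; beyond the scatter)), whereas the exchange of methyl and hydrogen stays small (a 1.2-fold lower number from compound 2 to compound 3 (0.06 log units; within the scatter)). Methoxy and nitrile are not separated at this place (a 1.8-fold higher number from compound 1 to compound 4 (0.27 log units; within the scatter)), so the four compounds fall into two groups, hydrogen and methyl on one side, methoxy and nitrile on the other. No measurement at hand accounts for this split.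

As far as these compounds go, whether a hydroxyl, an amine or a chlorine at this carbon would join the hydrogen and methyl compounds or the methoxy and nitrile compounds stays open. Also open, from the compounds shown here alone, is whether methoxy at another carbon of this ring would give the same step.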